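The compounds below may be only part of what the source reports. "The series", "measured", "known", "first", "only" and "open" are said of these compounds alone.

Working notes on the series built on the core of compound 1 `COc1cc2c(cc1OC)C(CC(=O)N(C)C)CC2`, which in a functional assay on the whole organism (strain Wistar) for inhibition, with Rattus norvegicus as the target, read by paw edema, with stated times of 60 min and 6 h, at a dose of 100 mg/kg by the oral route (a higher number here means more inhibition at the dose given (going by the name of the read-out), a lower number less inhibition), gives 33.3%. Compound 2 `COc1cc2c(cc1OC)C(CC(=O)NC(C)C)CC2` gives 37% and compound 3 `CCCCNC(=O)CC1CCc2cc(OC)c(OC)cc21` gives 24.1% in this assay. Among these three numbers compound 1 stands second highest; the nearest is compound 2, with a number 3.7 percentage points higher from compound 1 to compound 2 (within the scatter), and the furthest is compound 3, with a number 9.2 percentage points lower from compound 1 to compound 3 (within the scatter). Within the data shown here, the only step beyond the scatter is a number 12.9 percentage points lower from compound 2 to compound 3 (beyond the scatter).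

The unmeasured compound 4 `COc1cc2c(cc1OC)C(CC(=O)NC1CCCCC1)CC2` differs from compound 1 in one place: cyclohexylamino in place of dimethylamino on a carbonyl carbon. Among the measured compounds shown here, the steps that bear on this are the two from compound 1 to a secondary amide, a number 3.7 percentage points higher from compound 1 to compound 2 (within the scatter) and a number 9.2 percentage points lower from compound 1 to compound 3 (within the scatter), both within the scatter, and the step between the two secondary amides, a number 12.9 percentage points lower from compound 2 to compound 3 (beyond the scatter), which is modest. A branched substituent on the amide nitrogen, as in compound 2, sits on the higher side; a straight chain, as in compound 3, on the lower. Cyclohexylamino is a ring rather than a chain, so no step beyond the scatter is expected from compound 1, with an expected step of a number 3.7 percentage points higher from compound 1 to compound 4 (within the scatter). Compound 4 is accordingly estimated at 37%, with a range from 22% to 52%.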

Compound 4, a percentage reported as inhibition, in the whole organism at one dose (the size of the read-out at that dose, not a potency): 48.2%
Estimate against measurement, compound 4: 11.2 percentage points below; low and high end bracket the measured number.
By their numbers in this assay, from the lowest: compounds 3, 1 and 2 (each within the scatter of the next, the first and the last beyond it); then compound 4.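

Cyclohexylamino on the carbonyl carbon gives the first step from compound 1 that lies beyond the scatter, a number 14.9 percentage points higher from compound 1 to compound 4 (beyond the scatter), whereas the isopropylamino and butylamino steps from the same compound stayed within it. Compound 4 also stands clear of both other secondary amides in this assay, with a number 11.2 percentage points higher from compound 2 to compound 4 (beyond the scatter) and a number 24.1 percentage points higher from compound 3 to compound 4 (beyond the scatter), which makes it the highest of the four compounds at this dose. The group on the amide nitrogen therefore separates all three secondary amides, with the straight-chain butyl of compound 3 lowest, the branched isopropyl of compound 2 in the middle and the ring of compound 4 highest. No measurement at hand explains these differences.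

The compounds shown leave open whether the higher number belongs to cyclohexyl alone or extends to other rings on the amide nitrogen, such as cyclopentyl, phenyl or a piperidine ring taking in the nitrogen itself. With a single oral dose, they also leave open whether the gap between compound 4 and the other amides would persist at other doses.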